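Alkyl amine variants on the shared core: working notes

This account rests on a few compounds, and the source may have more. Where it says the series, first, only, none or still open, it means among the compounds named here.

Measured so far:
compound 1, `CCCCCCN[C@@H]1C=C[C@H](O)[C@H](O)[C@H]1O`: 56000 nM
compound 2, `CCC(CC)N[C@@H]1C=C[C@H](O)[C@H](O)[C@H]1O`: > 1000000 nM

In an assay for inhibition of beta-galactosidase (Homo sapiens), read by fluorescence, with a stated time of 30 min, at pH 4.5 (a higher number here means a weaker inhibitor, a lower number a stronger inhibitor), compound 1 gives 56000 nM. For compound 2 the reading is a limit of the assay, > 1000000 nM, and not a number. Compound 2 therefore stands at the weak edge of what has been measured, with no finite value of its own; the relevant point is the limit of > 1000000 nM in this assay, at which 1 of the 2 values shown sits.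

The next compound, compound 3 `CC(C)CCN[C@@H]1C=C[C@H](O)[C@H](O)[C@H]1O`, carries isopentyl in place of pentan-3-yl on an amine nitrogen. Going by the values given here, no step between measured compounds covers this change. The step from compound 2 to compound 3 is expected to run toward stronger inhibition, an at least 6.6-fold lower number from compound 2 to compound 3 (0.82 log units; beyond the scatter), and to exceed the usual scatter. Among the compounds with values here, with the hexyl analogue compound 1 at 56000 nM as the only finite reading in the set, compound 3 is estimated at 150000 nM, with a range from 40000 nM to 600000 nM. A further limit reading for compound 3 cannot be excluded.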

Compound 3, half-maximal inhibitory concentration: 28000 nM
For compound 3 the middle estimate is 5.4-fold (0.73 log units) above the measured one; the measured number lies below the stated range.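

With the same atoms joined differently, isopentyl in place of pentan-3-yl on an amine nitrogen gives an at least 35-fold lower number from compound 2 to compound 3 (1.55 log units; beyond the scatter) in this assay, so at this position the way the chain is joined matters and not only which atoms it holds. Isopropyl in place of butyl on a saturated chain carbon, two bonds along the chain from an amine nitrogen, gives a 2.0-fold lower number from compound 1 to compound 3 (0.30 log units; within the scatter), so hexyl and isopentyl read alike within the usual scatter and the shape change at that more distant place has no visible effect. Compound 2 is read only as a limit of the assay, which leaves the size of the first step open on one side: the limit of > 1000000 nM in this assay, at which 1 of the 3 values shown sits.

As far as these compounds go, whether pentan-3-yl stands alone or other groups on this amine nitrogen, such as isopropyl, cyclohexyl or cyclopentyl, behave like it remains open. Also open, from the compounds shown here alone, is whether a longer chain such as octyl, or a chain ending in a phenyl ring or a hydroxyl group, moves the reading in this assay beyond the level shared by compound 1 and compound 3.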